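Two cores and a nitro to trifluoromethyl swap

The source may report more compounds than this note shows. Statements on the series, on what has been measured and on what is new or still open speak of the compounds shown alone.

Compound 1 `COc1cccc2sc(NC(=O)c3ccc(C(F)(F)F)cc3)nc12`: > 10 ug/mL
Compound 2 `COc1cccc2sc(NC(=O)c3ccc([N+](=O)[O-])cc3)nc12`: > 10 ug/mL
Compound 3 `Cc1cc(C)c2sc(NC(=O)c3ccc([N+](=O)[O-])cc3)nc2c1`: 1.32 ug/mL

Three amides were tested in a functional assay on NUGC-3 cells (Homo sapiens) for antiproliferative activity, read by sulforhodamine B assay; on this read-out higher numbers stand for weaker inhibition of growth and lower numbers for stronger inhibition of growth. Compound 1 `COc1cccc2sc(NC(=O)c3ccc(C(F)(F)F)cc3)nc12` reaches only a limit there, > 10 ug/mL. Compound 2 `COc1cccc2sc(NC(=O)c3ccc([N+](=O)[O-])cc3)nc12` also reaches only a limit, > 10 ug/mL. Compound 3 `Cc1cc(C)c2sc(NC(=O)c3ccc([N+](=O)[O-])cc3)nc2c1` gives 1.32 ug/mL. The difference between the core of compound 2 and the core of compound 3 is not broken down here.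

Compound 1 and compound 2 differ by trifluoromethyl in place of nitro on an aromatic carbon. The step that the two limits leave unreadable from compound 2 to compound 1 stays unreadable, since both values sit at the limit of > 10 ug/mL in this assay, at which 2 of the 3 values shown sit.

The unmeasured compound 4 `Cc1cc(C)c2sc(NC(=O)c3ccc(C(F)(F)F)cc3)nc2c1` carries the same kind of change on the core of compound 3, (trifluoromethyl in place of nitro on an aromatic carbon). Whether the swap helps or hurts on this core cannot be read from compound 1 and compound 2, so the expectation rests on compound 3 and its value 1.32 ug/mL. The expected step is a 2.3-fold higher number from compound 3 to compound 4 (0.36 log units; beyond the scatter), leaning toward some loss. Compound 4 is estimated at 3 ug/mL, between 1 ug/mL and 10 ug/mL.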

Compound 4, concentration for 50% growth inhibition: 1.4 ug/mL
Compound 4: the middle estimate sits 2.1-fold (0.33 log units) above what was measured; measured number inside the range.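

In this assay, placing trifluoromethyl where nitro stood on the core of compound 3 gives a 1.1-fold higher number from compound 3 to compound 4 (0.03 log units; within the scatter), so on this core the two groups cannot be told apart, even though they differ in their atoms and in their hydrogen-bond acceptors. This is a single pair on a single core, and it does not show that the change is neutral across the series. Whether the result carries over to the core of compound 2 cannot be read, as the step to compound 1 has no size and both of these compounds give only a limit: the limit of > 10 ug/mL in this assay, at which 2 of the 4 values shown sit.

The compounds shown leave open whether the same place, on the aromatic carbon para to a large group, would tolerate an amine or a carboxylic acid as it tolerates nitro and trifluoromethyl on the core of compound 3. They also leave open how a nitrile there would compare with compound 3 and compound 4.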